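A few compounds are considered here, and "the series" means these few. Any claim that something is new, unique, unknown or untested is made for them only; others in the source may bear on it.

Measured so far in an ADME assay for permeability, using PAMPA, at pH 7.4; on this read-out higher numbers stand for higher permeability and lower numbers for lower permeability:
compound 1 `O=C(Nc1ccc(F)c(-c2nc3ccccc3o2)c1)c1cc([N+](=O)[O-])ccc1Cl` gives 366 10^-6 cm/s 
compound 2 `COc1ccc(-c2nc3ccccc3o2)cc1NC(=O)c1cc([N+](=O)[O-])ccc1Cl` gives 274 10^-6 cm/s 
compound 3 `O=C(Nc1cccc(-c2nc3ccccc3s2)c1)c1cc([N+](=O)[O-])ccc1Cl` gives 12 10^-6 cm/s 

Compound 3 stands lowest of the three, and its gaps to compound 1 and to compound 2 both lie beyond the usual scatter. Compound 1 and compound 2 lie within the scatter of each other. Both carry 1,3-benzoxazol-2-yl where compound 3 carries 1,3-benzothiazol-2-yl, but they also differ from compound 3 elsewhere, so neither gives a clean single-change comparison.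

Compound 4 `O=C(Nc1cccc(-c2nc3ccccc3o2)c1)c1cc([N+](=O)[O-])ccc1Cl` differs from compound 3 by 1,3-benzoxazol-2-yl in place of 1,3-benzothiazol-2-yl on an aromatic carbon and, in words, by 1,3-benzoxazol-2-yl in place of 1,3-benzothiazol-2-yl on an aromatic carbon. Among the compounds with values here, no measured pair isolates this change, so its size in this assay can only be inferred indirectly. The best available guide is that compound 2 at 274 10^-6 cm/s and compound 1 at 366 10^-6 cm/s both carry the entering group and both read well clear of compound 3. A rise beyond the scatter is therefore expected, though the unshared differences leave its size uncertain. The expected change is an 11-fold higher number from compound 3 to compound 4 (1.03 log units; beyond the scatter) in this read-out. For compound 4 the estimated value is 130 10^-6 cm/s (expected range 30 10^-6 cm/s to 400 10^-6 cm/s).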

Compound 4, apparent permeability: 45 10^-6 cm/s
Compound 4: the middle estimate sits 2.9-fold (0.46 log units) above what was measured, and the stated range covers the measured number.
By their numbers in this assay, from the lowest: compound 3; then compound 4; then compounds 2 and 1 (each within the scatter of the next).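

Read as a single change, 1,3-benzoxazol-2-yl in place of 1,3-benzothiazol-2-yl on an aromatic carbon gives a 3.8-fold higher number from compound 3 to compound 4 (0.57 log units; beyond the scatter) in this assay, so this exchange at this position moves the read-out by itself, without any other difference in the structure. It does not carry the whole distance up to the two earlier benzoxazol-2-yl compounds: with that group held constant, hydrogen in place of methoxy gives a 6.1-fold lower number from compound 2 to compound 4 (0.78 log units; beyond the scatter) and hydrogen in place of fluoro gives an 8.1-fold lower number from compound 1 to compound 4 (0.91 log units; beyond the scatter), so among these compounds the unsubstituted ring goes with the lower number in both comparisons. No measurement bearing on the reason for any of these steps is available.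

Going by these compounds, whether methoxy or fluoro would raise the number to a similar extent alongside 1,3-benzothiazol-2-yl remains open, since both substituents appear here only with 1,3-benzoxazol-2-yl. On these data alone, it is also open how an amine, a carboxylic acid or a longer alkoxy chain in place of that hydrogen would read in this assay on the core of compound 4.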